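The source may hold more compounds than are shown below. What is called first, only, known or untested is meant among the compounds shown, and "the series" means these compounds.

Of the compounds shown here, two have so far been measured in a functional assay on MIA PaCa-2 cells (Homo sapiens) for inhibition, read by MTT assay, with a stated time of 72 h; on this read-out lower numbers stand for stronger inhibition of growth and higher numbers for weaker inhibition of growth. Compound 1 `O=S(=O)(NCCNCc1cccc2ccccc12)c1cc(C(F)(F)F)cc(C(F)(F)F)c1` gives 26000 nM in this assay. Compound 2 `O=S(=O)(NCCCCCCNCc1ccc(Br)cc1)c1cc(Cl)cc(Cl)c1` gives 12000 nM in this assay. Of these two numbers, compound 2 holds the lower one, and the gap to compound 1 lies beyond the usual scatter, so compound 2 stands as the stronger inhibitor of growth in this pair.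

Compound 3 `CC(C)c1ccc(S(=O)(=O)NCCCCCCNCc2ccc(Br)cc2)cc1` has not yet been measured. It differs from compound 2 in a single place: 4-isopropylphenyl in place of 3,5-dichlorophenyl on a sulfonyl sulfur. The rest of the molecule, the chain and the group at its far end, is kept as in compound 2. For the measured compounds named here, no measured pair shows this exact exchange on the sulfonyl sulfur, so nothing can be read off directly about its effect. One aromatic ring of carbon only is exchanged for another, with no change in donors, acceptors or charge, and the expectation is therefore a step from compound 2 to compound 3 of a 1.3-fold higher number from compound 2 to compound 3 (0.10 log units; within the scatter), that is, no step beyond the scatter, with a weakening slightly more likely than a strengthening. On that basis compound 3 is estimated to give 15000 nM in this assay, with a range from 5000 nM to 45000 nM.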

Compound 3, concentration for 50% growth inhibition: 5730 nM
Compound 3: the middle estimate sits 2.6-fold (0.42 log units) above what was measured; the range from low to high includes it.
By their numbers in this assay, from the lowest: compound 3; then compound 2; then compound 1.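

For the compounds shown here, the exchange on the sulfonyl sulfur is the first single change that can be read on its own in this assay and it gives a 2.1-fold lower number from compound 2 to compound 3 (0.32 log units; beyond the scatter) with the chain and the group at its far end kept the same. This shows that the position is not indifferent to which aromatic ring of carbon only it carries, even though 3,5-dichlorophenyl and 4-isopropylphenyl have the same counts of hydrogen-bond donors and acceptors and neither has a net charge. No measurement offered here accounts for the direction or size of this modest step.

The compounds shown leave open whether the step comes from losing the two chlorine atoms, from gaining the isopropyl group, or from both, a question that 4-chlorophenyl or 4-tert-butylphenyl on the sulfonyl sulfur could help to separate. They also leave open whether the same exchange would give a similar step with a shorter chain or with a carboxylic acid at the far end.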